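This account rests on a few compounds, and the source may have more. Where it says the series, first, only, none or still open, it means among the compounds named here.

In an ADME assay on microsomes from liver (Rattus norvegicus) for metabolic stability, read by LC-MS, with a stated time of 10 min, tested at 0.5 uM (a lower number here means that less of the compound is left, a higher number that more of the compound is left), compound 1 `c1ccc2c(c1)CN[C@H](CN(CCCN1CCNCC1)[C@H]1CCCc3cccnc31)C2` stands highest of the three measured compounds (88%). Compound 2 `CC(C)N1CCN(CCCN(C[C@H]2Cc3ccccc3CN2)[C@H]2CCCc3cccnc32)CC1` gives 4% and compound 3 `CCN1CCN(CCCN(C[C@H]2Cc3ccccc3CN2)[C@H]2CCCc3cccnc32)CC1` gives 1%. The gaps from compound 1 to these two compounds both lie beyond the scatter. Compound 4 `c1cnc2c(c1)CN[C@H](CN(CCCN1CCNCC1)[C@H]1CCCc3cccnc31)C2` differs from compound 1 in one place (a group of 10 heavy atoms (8 carbon, 2 nitrogen; one six-membered non-aromatic ring with 1 hetero atom, one six-membered aromatic ring with 1 hetero atom) in place of a group of 10 heavy atoms (9 carbon, 1 nitrogen; one six-membered non-aromatic ring with 1 hetero atom, one six-membered aromatic ring of carbon only), on a saturated chain carbon bound to an amine nitrogen): the six-membered aromatic ring of carbon only gives way to one with 1 hetero atom. Within the data shown here, the only measured single-place step (a number 3 percentage points lower from compound 2 to compound 3 (within the scatter)) lies within the scatter and involves a different change, so no measured step shows this exchange directly. The expectation therefore rests on compound 1 (88%), and no step beyond the scatter is expected (a number 4 percentage points lower from compound 1 to compound 4 (within the scatter)). Compound 4 is estimated at 84% (62% to 98%).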

Compound 4, percent of the compound remaining: 87%
The estimate for compound 4 lay 3 percentage points below the measured number, within the range that was stated.
By their numbers in this assay, from the lowest: compounds 3 and 2 (each within the scatter of the next); then compounds 4 and 1 (each within the scatter of the next).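

In this assay, replacing the 1,2,3,4-tetrahydroisoquinolin-3-yl group on a saturated chain carbon bound to an amine nitrogen with its counterpart bearing a hetero atom in the aromatic ring gives a number 1 percentage points lower from compound 1 to compound 4 (within the scatter). Among these compounds, this is the first direct reading of a change at this place, and the aromatic ring of carbon only gives way to one with a hetero atom with no shift beyond the scatter. Going by these compounds, whether a chlorine atom or a methoxy group on this aromatic ring would also leave the percent remaining unchanged stays open. No measured information explains the result.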